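Swapping piperidin-1-yl for methylsulfanyl: expected tolerance shift

The source may hold more compounds than are shown below. What is called first, only, known or untested is meant among the compounds shown, and "the series" means these compounds.

Compound 1, `[N-]=[N+]=NCc1ncnc2c1ncn2[C@@H]1O[C@H](CO)[C@@H](O)[C@H]1O`, in a functional assay on Huh-7 cells (Homo sapiens) for cytotoxicity, read by MTT assay, with a stated time of 3 days (a lower number here means that less compound is tolerated, a higher number that more compound is tolerated), gives a limit of > 250000 nM.
Compound 2, `OCCSCc1ncnc2c1ncn2[C@@H]1O[C@H](CO)[C@@H](O)[C@H]1O`, in this assay gives a limit of > 100000 nM.
Compound 3, `OC[C@H]1O[C@@H](n2cnc3c(CN4CCCCC4)ncnc32)[C@H](O)[C@@H]1O`, in this assay gives 87000 nM.

Going by the values given here, compound 3 stands apart as the only measured number among the three; the other two values stop at the limit of > 100000 nM in this assay, at which 1 of the 3 values shown sits, and (the limit of > 250000 nM in this assay, at which 1 of the 3 values shown sits). The step of an at least 2.8-fold lower number from compound 1 to compound 3 (0.45 log units; beyond the scatter) shows that compound 3 is tolerated less well than the azido parent, while an at least 1.1-fold lower number from compound 2 to compound 3 (0.06 log units; that floor lies within the scatter) and a step that the two limits leave unreadable from compound 1 to compound 2 give little beyond a floor. Compound 4, `CSCc1ncnc2c1ncn2[C@@H]1O[C@H](CO)[C@@H](O)[C@H]1O`, differs from compound 3 by methylsulfanyl in place of piperidin-1-yl on a saturated chain carbon bound to an aromatic carbon. The nearest guide is compound 2, whose sulfanyl-bearing chain gave a limit; since an at least 1.1-fold lower number from compound 2 to compound 3 (0.06 log units; that floor lies within the scatter) was read toward compound 3, the reverse direction is expected here. Compound 4 is therefore expected to return a higher number, with a 1.7-fold higher number from compound 3 to compound 4 (0.24 log units; within the scatter). The estimate for compound 4 is 150000 nM, with a range from 60000 nM to 300000 nM, and a real chance that only a limit is reported.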

Compound 4, half-maximal cytotoxic concentration: > 100000 nM
Compound 4: only a limit was reported (the forecaster's own chance of this, stated with the estimate: 60%); the middle value does not contradict the limit.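

Putting methylsulfanyl in place of piperidin-1-yl on a saturated chain carbon bound to an aromatic carbon yields an at least 1.1-fold higher number from compound 3 to compound 4 (0.06 log units; that floor lies within the scatter) in this assay and so does not establish any shift in tolerance. Going by these compounds alone, what is new is that a sulfanyl chain without the hydroxymethyl end of compound 2 also stops at a limit, leaving compound 3 as the only compound here with a measured number: the limit of > 100000 nM in this assay, at which 2 of the 4 values shown sit. The steps that join compound 1, compound 2 and compound 4 to one another cannot be read, as each links two limits.

Going by these compounds, how far the true values of compound 2 and compound 4 lie past their limits remains open. Also open, on these data alone, is whether an open-chain amine such as dimethylamino, or a carboxylic acid, on this same carbon would give a measured number as compound 3 does.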